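The source may hold more compounds than are shown below. What is called first, only, known or untested is meant among the compounds shown, and "the series" means these compounds.

Two compounds share one core and differ only in the group on the carbonyl carbon. In a functional assay on PC-3 cells (Homo sapiens) for cytotoxicity, read by MTT assay, with a stated time of 48 h (a higher number here means a weaker inhibitor, a lower number a stronger inhibitor), compound 1 `COc1cc(-c2nnc3n2NC(c2ccco2)C(C(=O)c2ccc(Br)cc2)S3)cc(OC)c1OC` gives 36400 nM, and compound 2 `COc1cc(-c2nnc3n2NC(c2ccco2)C(C(=O)c2ccc(C)cc2)S3)cc(OC)c1OC` gives 7500 nM. For the measured compounds named here, the only measured step is a 4.9-fold lower number from compound 1 to compound 2 (0.69 log units; beyond the scatter), which leaves compound 2 with the lower of the two numbers. Compound 3 `COc1cc(-c2nnc3n2NC(c2ccco2)C(C(=O)c2cccc4ccccc24)S3)cc(OC)c1OC` carries a different change: naphthalen-1-yl in place of 4-methylphenyl on a carbonyl carbon. Going by the values given here, no measured step tests this kind of change, so the expected step in this assay is a 1.1-fold higher number from compound 2 to compound 3 (0.03 log units; within the scatter), none beyond the scatter. For compound 3 the estimate in this assay is 8000 nM, with a range from 2500 nM to 30000 nM.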

Compound 3, half-maximal inhibitory concentration: > 100000 nM
Compound 3: only a limit was reported (the forecaster's own chance of this, stated with the estimate: 5%); middle value at least 12-fold (1.09 log units) from the limit.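

The group on the carbonyl carbon matters far more than the two earlier compounds suggested: naphthalen-1-yl in place of 4-methylphenyl gives an at least 13-fold higher number from compound 2 to compound 3 (1.12 log units; beyond the scatter), and in place of 4-bromophenyl it gives an at least 2.7-fold higher number from compound 1 to compound 3 (0.43 log units; beyond the scatter). Both steps are minimum sizes, since compound 3 gives only a limit in this assay: the limit of > 100000 nM in this assay, at which 1 of the 3 values shown sits.

The earlier pair changed only the group on the phenyl ring and both gave numbers, whereas a second six-membered aromatic ring here leaves no number at all.

From the compounds shown here alone, how far compound 3 lies past its limit stays open. So does whether naphthalen-2-yl, cyclohexyl or a phenyl ring bearing an amine would behave like compound 2 or like compound 3.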